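The source may hold more compounds than are shown below. What is called first, only, known or untested is meant among the compounds shown, and "the series" means these compounds.

Three compounds that share one core have been examined in a functional assay on the whole organism for inhibition, with Rattus norvegicus as the target, read by paw edema, with stated times of 30 min and 2 h, at a dose of 10 mg/kg by the oral route; a higher number here means more inhibition at the dose given (going by the name of the read-out), a lower number less inhibition. Compound 1 `O=C1N=C(C2C(=O)c3ccccc3C2=O)CC(c2ccccc2[N+](=O)[O-])N1` gives 30%, compound 2 `O=C1N=C(C2C(=O)c3ccccc3C2=O)CC(c2ccccc2)N1` gives 33%, and compound 3 `COc1ccc(C2CC(C3C(=O)c4ccccc4C3=O)=NC(=O)N2)cc1` gives 21%, the lowest of the three numbers; its gap to compound 1 lies within the scatter, whereas the step of a number 12 percentage points lower from compound 2 to compound 3 (beyond the scatter) is modest but beyond it. Compound 4 `O=C1N=C(C2C(=O)c3ccccc3C2=O)CC(c2cccc([N+](=O)[O-])c2)N1` differs from compound 3 in one place: 3-nitrophenyl in place of 4-methoxyphenyl on a saturated ring carbon. The measured steps that bear on this change are a number 9 percentage points lower from compound 1 to compound 3 (within the scatter) and a number 3 percentage points higher from compound 1 to compound 2 (within the scatter), both within the scatter, together with a number 12 percentage points lower from compound 2 to compound 3 (beyond the scatter). Reversing the methoxyphenyl for a nitrophenyl is therefore expected to carry this assay modestly upward, by about a number 7 percentage points higher from compound 3 to compound 4 (within the scatter). Compound 4 is accordingly estimated at 28%, within a range from 15% to 42%.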

Compound 4, a percentage reported as inhibition, in the whole organism at one dose (the size of the read-out at that dose, not a potency): 36%
The estimate for compound 4 lay 8 percentage points below the measured number, within the range that was stated.
By their numbers in this assay, from the lowest: compounds 3, 1, 2 and 4 (each within the scatter of the next, the first and the last beyond it).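

On the saturated ring carbon, this assay shows a number 15 percentage points higher from compound 3 to compound 4 (beyond the scatter) when 3-nitrophenyl replaces 4-methoxyphenyl. Nitro in place of hydrogen gives a number 3 percentage points higher from compound 2 to compound 4 (within the scatter) and 3-nitrophenyl in place of 2-nitrophenyl gives a number 6 percentage points higher from compound 1 to compound 4 (within the scatter), so at this level neither the presence of the nitro group nor the difference between these two nitrophenyl groups can be read. Compound 4 joins compound 2 in standing beyond the scatter from compound 3, whereas compound 1 does not. The compounds shown leave open how an amine or a carboxylic acid on the aromatic ring would fare, and nothing measured here explains these numbers.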